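Swapping a Chlorophenyl for a Dihydroxyphenyl Group

The source may hold more compounds than are shown below. What is called first, only, known or untested is meant among the compounds shown, and "the series" means these compounds.

Measured so far:
compound 1, `CCOC(=O)c1cnn(-c2nc(-c3ccccc3Cl)c(C#N)c(=O)n2C)c1N`: 102 ug/mL
compound 2, `CN(C)c1ccc(-c2nc(NN)n(C)c(=O)c2C#N)cc1`: 63 ug/mL

Both compounds were tested in a functional assay on microsomes for inhibition, with a stated time of 1 h; a lower number here means a stronger inhibitor, a higher number a weaker inhibitor. In this assay compound 1 gives 102 ug/mL, and compound 2 gives 63 ug/mL. The two numbers lie within the usual scatter of each other, so neither compound can be called the stronger or the weaker inhibitor; compound 1 simply stands alongside compound 2 at the weak end of what is shown here.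

The next compound, compound 3, `CCOC(=O)c1cnn(-c2nc(-c3cccc(O)c3O)c(C#N)c(=O)n2C)c1N`, shares the core of compound 1 and differs from it in one place: 2,3-dihydroxyphenyl in place of 2-chlorophenyl on an aromatic carbon. For the measured compounds named here, no pair of measured compounds shows what such a change does in this assay, so there is nothing to guide the size or direction of the step. The expectation for the step from compound 1 to compound 3 is therefore a 1.1-fold lower number from compound 1 to compound 3 (0.03 log units; within the scatter), that is, no change beyond the scatter, with a wide range to allow for either direction.

Compound 3 is thus estimated to give 95 ug/mL in this assay, within a range from 35 ug/mL to 260 ug/mL.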

Compound 3, half-maximal inhibitory concentration: 49 ug/mL
Compound 3: the middle estimate sits 1.9-fold (0.29 log units) above what was measured; low and high end bracket the measured number.
By their numbers in this assay, from the lowest: compounds 3, 2 and 1 (each within the scatter of the next, the first and the last beyond it).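

In this assay, putting 2,3-dihydroxyphenyl in place of 2-chlorophenyl gives a 2.1-fold lower number from compound 1 to compound 3 (0.32 log units; beyond the scatter), a modest step, but one that lies beyond the usual scatter. For the compounds shown here, this is the first pair here that differs in only one place, and it shows that the group on this aromatic carbon, ortho to a cyano group, can shift the number, and that this exchange shifts it towards stronger inhibition while the rest of compound 1 stays the same. The entering group brings hydrogen-bond donors and acceptors where the leaving group has none, but no measurement here connects that difference to the result, so the reason for the step remains unknown.

The exchange removes the chlorine and adds the hydroxyl groups in a single move, so these compounds cannot show whether the step comes from losing one, gaining the other, or both. As far as these compounds go, a plain phenyl ring, or a phenyl ring carrying one hydroxyl or methoxy group, on the same core would help separate these contributions, and it remains open how such groups would compare with compound 3.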